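Adding a second chloro to the shared core

This account rests on a few compounds, and the source may have more. Where it says the series, first, only, none or still open, it means among the compounds named here.

Measured compounds in a functional assay on UO-31 cells (Homo sapiens) for cytotoxicity, read by sulforhodamine B assay, with a stated time of 48 h; on this read-out lower numbers stand for higher toxicity in this test and higher numbers for lower toxicity in this test:
compound 1 `ClCc1ccc(Cn2cnc3c(Cl)ncnc32)cc1` — > 100000 nM
compound 2 `ClCc1cccc(Cn2cnc3c(Cl)nc(Cl)nc32)c1` — 5880 nM
compound 3 `ClCc1ccc(Cn2cnc3c(Cl)nc(Cl)nc32)cc1` — not yet measured

Compound 1 stands at a limit of this assay, reported as > 100000 nM, which is the case noted in the limit of > 100000 nM in this assay, at which 1 of the 2 values shown sits. In this assay compound 2 gives 5880 nM, a number rather than a limit. Going by the values given here, compound 2 differs from compound 1 in two places, so the two values show only that one compound reaches a number and the other does not; no single step connects them.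

Compound 3 differs from compound 1 by chloro in place of hydrogen on an aromatic carbon. Among the compounds with values here, no measured step covers this change. Compound 2 carries the same chloro on its core and gives 5880 nM, so the step from compound 1 to compound 3 is expected to lower the number beyond the scatter, that is towards higher toxicity, an at least 8.3-fold lower number from compound 1 to compound 3 (0.92 log units; beyond the scatter). Compound 3 is estimated at 12000 nM, with an expected range from 3000 nM to 60000 nM, while a repeat of a limit instead of a number remains possible.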

Compound 3, concentration lethal to 50% of the cells: 66100 nM
For compound 3 the middle estimate is 5.5-fold (0.74 log units) below the measured one; measured number outside the range, above it.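

In this assay, chloro in place of hydrogen on an aromatic carbon, between two ring nitrogen atoms, gives a change that can be stated only as a floor: an at least 1.5-fold lower number from compound 1 to compound 3 (0.17 log units; that floor lies within the scatter). The change does take the series from a limit to a number, but that alone does not establish a real gain in toxicity in this test. The chloro does not fix the value by itself, since compound 3 gives 66100 nM while compound 2, which carries the same chloro on the core, gives 5880 nM. The true size of the step stays unknown because compound 1 stands at a limit: the limit of > 100000 nM in this assay, at which 1 of the 3 values shown sits.

Still open, from the compounds shown here alone, is whether an amine, a methoxy group or fluoro at this same position would bring a number in this assay, and how any of them would compare with chloro. Also open, going by these compounds, is what happens to the values when the chloromethyl group gives way to a hydroxymethyl group or a longer chain while the two chloro groups on the core stay in place.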